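The source may report more compounds than this note shows. Statements on the series, on what has been measured and on what is new or still open speak of the compounds shown alone.

Compound 1, `CO[C@H]1C=C(COC(C)=O)C(=O)[C@@H]2O[C@@](C)(OC)[C@](C)(OC)O[C@@H]12`: "not determined" (no result reported)
Compound 2, `CO[C@]1(C)O[C@H]2[C@H](O)C=C(COC(C)=O)C(=O)[C@@H]2O[C@@]1(C)OC`: > 100000 nM
Compound 3, `CO[C@]1(C)O[C@H]2[C@H](O)C(CO)=CC(=O)[C@@H]2O[C@@]1(C)OC`: > 100000 nM

In an assay on isolated protein for inhibition of glutathione S-transferase A2 (Homo sapiens), read by spectrophotometry, with a stated time of 3 min (a higher number here means a weaker inhibitor, a lower number a stronger inhibitor), compound 1 carries no single number. For compound 2 the result in this assay is a limit, not a number. For compound 3 the result in this assay is likewise a limit. Going by the values given here, two of the three entries therefore sit at the limit of > 100000 nM in this assay, at which 2 of the 3 values shown sit, and no step between measured compounds is available.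

Compound 4, `CO[C@]1(C)O[C@H]2[C@@H](OC/C=C(\C)CCC=C(C)C)C=C(COC(C)=O)C(=O)[C@@H]2O[C@@]1(C)OC`, differs from compound 1 by 2,6-dimethylhepta-1,5-dien-1-yl in place of hydrogen on a saturated chain carbon bound to an oxygen on a saturated carbon. Among the compounds with values here, with no measured step to lean on, the account expects no change beyond the usual scatter in this assay, in either direction. Compound 4 is accordingly estimated at 150000 nM in this assay, within a range from 30000 nM to 800000 nM.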

Compound 4, half-maximal inhibitory concentration: 179000 nM
Compound 4: the middle estimate sits 1.2-fold (0.08 log units) below what was measured; the measured number falls inside the stated range.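

No new step can be read for compound 4, since compound 1 carries no single number in this assay. The compounds shown leave open whether (3,7-dimethylocta-2,6-dien-1-yl)oxy in place of methoxy alters inhibition on the shared core.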